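Dropping the ring hydroxy group from a weak binder

The source may report more compounds than this note shows. Statements on the series, on what has been measured and on what is new or still open speak of the compounds shown alone.

Two compounds with a shared core have been measured in an assay on isolated protein for binding affinity to Adrenergic receptor alpha-1 (Rattus norvegicus), read by radioligand binding; a higher number here means a weaker inhibitor, a lower number a stronger inhibitor:
compound 1 `Cc1ccc(CC2(O)CCN(CCC#Cc3ccc(N)cc3)CC2)cc1` gives 85000 nM
compound 2 `Nc1ccc(C#CCCN2CCC(O)(Cc3ccc(F)cc3)CC2)cc1` gives 31000 nM

Among the compounds with values here, compound 2 holds the lower of the two numbers; its nearest neighbour is compound 1, and the only recorded step is a 2.7-fold lower number from compound 1 to compound 2 (0.44 log units; beyond the scatter), a fluoro in place of methyl on an aromatic carbon. Compound 3 `Nc1ccc(C#CCCN2CCC(Cc3ccc(F)cc3)CC2)cc1` differs from compound 2 by hydrogen in place of hydroxy on a saturated ring carbon. Within the data shown here, none of the measured steps bears on this change: the single step available concerns a substituent on the aromatic ring, not the saturated ring carbon, so there is nothing in the data that points in either direction. The step from compound 2 to compound 3 in this assay is therefore expected to be none beyond the scatter, a 1.0-fold lower number from compound 2 to compound 3 (0.01 log units; within the scatter). Compound 3 is estimated at 30000 nM, with a range from 9000 nM to 100000 nM.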

Compound 3, half-maximal inhibitory concentration: 700 nM
For compound 3 the middle estimate is 43-fold (1.63 log units) above the measured one, outside the stated range (below it).
By their numbers in this assay, from the lowest: compound 3; then compound 2; then compound 1.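

In this assay, the saturated ring carbon three ring bonds from the ring nitrogen proves far more sensitive than the aromatic position: hydrogen in place of hydroxy gives a 44-fold lower number from compound 2 to compound 3 (1.65 log units; beyond the scatter) and is a large step, whereas fluoro in place of methyl gives only the modest 2.7-fold lower number from compound 1 to compound 2 (0.44 log units; beyond the scatter) on the aromatic carbon. Compound 3, which lacks the hydroxy group, therefore has the lowest number of the three compounds. Nothing available explains why this single change has so large an effect.

On these data alone, whether a methoxy group, a fluoro or an amine on this ring carbon would give a number closer to that of compound 2 or of compound 3 remains open. As far as these compounds go, it is also open whether the same step would appear with methyl in place of the aromatic fluoro.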